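Aryl ketone changes on the shared core: working notes

The compounds below may be only part of what the source reports. "The series", "measured", "known", "first", "only" and "open" are said of these compounds alone.

Measured in a functional assay on OVCAR-4 cells (Homo sapiens) for inhibition, read by sulforhodamine B assay, with a stated time of 48 h; on this read-out higher numbers stand for weaker inhibition of growth and lower numbers for stronger inhibition of growth:
compound 1 `COc1cc(-c2cc(/C=C/C(=O)c3ccc(N)cc3)[nH]n2)cc(OC)c1OC`: 1400 nM
compound 2 `COc1cc(-c2cc(/C=C/C(=O)c3ccc(Cl)c(Cl)c3)[nH]n2)cc(OC)c1OC`: 10800 nM
compound 3 `COc1ccc(C(=O)/C=C/c2cc(-c3cc(OC)c(OC)c(OC)c3)n[nH]2)cc1`: 2200 nM

Compound 3 stands second highest of the three numbers. One step to it lies within the scatter, a 1.6-fold higher number from compound 1 to compound 3 (0.20 log units; within the scatter); the other lies beyond it, a 4.9-fold lower number from compound 2 to compound 3 (0.69 log units; beyond the scatter).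

Compound 4 `COc1cc(-c2cc(/C=C/C(=O)c3ccc(F)c(F)c3)[nH]n2)cc(OC)c1OC` differs from compound 3 by 3,4-difluorophenyl in place of 4-methoxyphenyl on a carbonyl carbon. The step that bears on this is a 4.9-fold lower number from compound 2 to compound 3 (0.69 log units; beyond the scatter), which run the other way points to a higher number for a dihalogenated ring; a 7.7-fold higher number from compound 1 to compound 2 (0.89 log units; beyond the scatter) points the same way. Nothing here separates difluoro from dichloro. A step toward weaker inhibition is therefore expected, a 2.5-fold higher number from compound 3 to compound 4 (0.40 log units; beyond the scatter). For compound 4 the estimate is 5500 nM, in the range 2200 nM to 14000 nM.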

Compound 4, concentration for 50% growth inhibition: 2200 nM
The estimate for compound 4 lay 2.5-fold (0.40 log units) above the measured number, and the stated range covers the measured number.
By their numbers in this assay, from the lowest: compounds 1, 3 and 4 (each within the scatter of the next); then compound 2.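

In this assay the two dihalogenated rings on the carbonyl carbon part ways: a 4.9-fold lower number from compound 2 to compound 4 (0.69 log units; beyond the scatter) ties the high number of compound 2 to 3,4-dichlorophenyl, not to two halogens as such. Against the other rings, 3,4-difluorophenyl shows no change at the digits printed from compound 3 to compound 4 (within the scatter) and a 1.6-fold higher number from compound 1 to compound 4 (0.20 log units; within the scatter) and so stands level with 4-methoxyphenyl and 4-aminophenyl. No supporting data explain the difference between the fluorinated and chlorinated rings.

From the compounds shown here alone, whether 4-fluorophenyl, 4-chlorophenyl or unsubstituted phenyl would sit with compound 4 or with compound 2 stays open. So does the reading for a carboxylic acid on this ring.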